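The compounds below may be only part of what the source reports. "The series", "measured", "known", "first", "only" and "open" are said of these compounds alone.

Of the compounds shown here, two with a shared core have been measured in a functional assay on isolated protein for inhibition of Glucose-dependent insulinotropic receptor (Rattus norvegicus), read by HTRF and cAMP accumulation; on this read-out lower numbers stand for smaller maximal responses and higher numbers for larger maximal responses. Compound 1 `Cc1nc(S(C)(=O)=O)ccc1Oc1ncnc(OC2CCN(C(=O)OC(C)F)CC2)c1F` gives 68% in this assay. Among the compounds with values here, compound 2 `Cc1nc(S(C)(=O)=O)ccc1Oc1ncnc(OC2CCN(C(=S)OC3(C)CC3)CC2)c1F` gives 49%, which is the lower of the two numbers; the only other compound, compound 1, stands higher by the step of a number 19 percentage points lower from compound 1 to compound 2 (beyond the scatter), and that difference is beyond the usual scatter.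

Compound 3 `Cc1nc(S(C)(=O)=O)ccc1Oc1ncnc(OC2CCN(C(=O)c3noc(C(C)(C)F)n3)CC2)c1F` is not yet measured. It differs from compound 2 in the group attached to the amine nitrogen in the ring: a group of 11 heavy atoms (6 carbon, 2 nitrogen, 2 oxygen, 1 fluorine; one five-membered aromatic ring with 3 hetero atoms) in place of a group of 7 heavy atoms (5 carbon, 1 oxygen, 1 sulfur; one three-membered non-aromatic ring of carbon only), on an amine nitrogen in a ring.

Within the data shown here, the only measured step bears on the same position. From compound 1 to compound 2 a change at this nitrogen moved the maximal response modestly, as the step of a number 19 percentage points lower from compound 1 to compound 2 (beyond the scatter) shows. That step does not involve the group that enters in compound 3, so it only shows that changes at this position move the read-out by modest amounts. A step of similar size in either direction, or none beyond the scatter, is therefore plausible. On that basis the step is estimated at a number 9 percentage points higher from compound 2 to compound 3 (within the scatter).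

Compound 3 is estimated to give 58% in this assay, within a range from 38% to 78%.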

Compound 3, largest response reached (reported as efficacy), in percent of the reference or control that the assay uses: 74%
Estimate against measurement, compound 3: 16 percentage points below; the measured number falls inside the stated range.
By their numbers in this assay, from the lowest: compound 2; then compounds 1 and 3 (each within the scatter of the next).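

At the amine nitrogen in the ring, putting the group with a five-membered aromatic ring with 3 hetero atoms in place of the group with a three-membered non-aromatic ring of carbon only gives a number 25 percentage points higher from compound 2 to compound 3 (beyond the scatter) in this assay, so a change at this position can raise the maximal response as well as lower it. On the carbonyl carbon, the same aromatic ring in place of the small group with no ring gives a number 6 percentage points higher from compound 1 to compound 3 (within the scatter), which means that this read-out does not separate these two groups, and compound 3 goes against any idea that more heavy atoms at this position simply mean a lower number. No measurement shown here accounts for these shifts.

As far as these compounds go, it remains open what a methyl, an amine or a carboxylic acid would do in place of the fluorine-bearing group on the aromatic ring. It is also unknown whether the low number of compound 2 goes with its sulfur atom or with its three-membered ring, since these two features differ together in the compounds shown.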